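A few compounds are considered here, and "the series" means these few. Any claim that something is new, unique, unknown or untested is made for them only; others in the source may bear on it.

Measured compounds:
Compound 1 `CCC(/C=C1\OC(=O)NC1=O)(CC)c1ccc(-c2ccc3cc(F)cc(F)c3c2)[nH]c1=O`: 28 nM
Compound 2 `CC(C)(/C=C1\OC(=O)NC1=O)c1ccc(-c2ccc3cccc(F)c3c2)[nH]c1=O`: 38 nM
Compound 3 `CC(C)[C@@H](c1ccc(-c2ccc3cccc(F)c3c2)[nH]c1=O)[C@H]1OC(=O)NC1=O`: 27 nM

All three were tested in an assay on membranes from Chem-1 cells for displacement of a labelled ligand from prostaglandin E2 receptor EP3 subtype (Homo sapiens), read by scintillation counting, with a stated time of 2 h; on this read-out lower numbers stand for stronger inhibition and higher numbers for weaker inhibition. Compound 3 gives the lowest of the three numbers, but its gap to compound 1 and its gap to compound 2 both lie within the usual scatter, so no order among them can be claimed. Compound 4 `CC(C)[C@H](C[C@@H]1OC(=O)NC1=O)c1ccc(-c2ccc3cccc(F)c3c2)[nH]c1=O` differs from compound 3 in one place: (2,4-dioxo-1,3-oxazolidin-5-yl)methyl in place of 2,4-dioxo-1,3-oxazolidin-5-yl on a saturated chain carbon bound to an aromatic carbon and a saturated chain carbon. Going by the values given here, no step of this kind has been measured here; since compounds 1, 2 and 3, which carry their ring on differing linkers, all sit close together, the step is expected to be small and within the scatter in either direction. Compound 4 is therefore estimated to give 35 nM, with a range from 12 nM to 110 nM, an expected step of a 1.3-fold higher number from compound 3 to compound 4 (0.11 log units; within the scatter).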

Compound 4, inhibition constant in the prostaglandin E2 receptor EP3 subtype assay: 8 nM
Estimate against measurement, compound 4: 4.4-fold (0.64 log units) above; measured number outside the range, below it.
By their numbers in the prostaglandin E2 receptor EP3 subtype assay, from the lowest: compound 4; then compounds 3, 1 and 2 (each within the scatter of the next).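

Going by these compounds alone, in the prostaglandin E2 receptor EP3 subtype assay the change to (2,4-dioxo-1,3-oxazolidin-5-yl)methyl on this saturated chain carbon gives a 3.4-fold lower number from compound 3 to compound 4 (0.53 log units; beyond the scatter) and lies beyond the scatter, so this position responds to the linker in a way the close values of the earlier compounds did not reveal. In a physicochemical assay for solubility, in phosphate buffer, measured as kinetic solubility (on this read-out higher numbers stand for higher solubility and lower numbers for lower solubility), compound 3 gives 31600 nM and compound 4 gives 21100 nM as values, and a 1.5-fold lower number from compound 3 to compound 4 (0.18 log units; within the scatter) stays within the scatter. Nothing given here explains the step.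

As far as these compounds go, whether a longer chain carrying the same ring lowers the number further remains open, as does whether a carboxylic acid can stand in place of the ring.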